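From Cyclopropyl to Pyrimidin-5-yl on a Growth Inhibitor

A few compounds are considered here, and "the series" means these few. Any claim that something is new, unique, unknown or untested is made for them only; others in the source may bear on it.

For the measured compounds named here, in a functional assay on HCT-116 cells (Homo sapiens) for inhibition, read by MTT assay, with a stated time of 72 h (a lower number here means a stronger inhibitor of growth, a higher number a weaker inhibitor of growth), compound 1 `COc1ccc(-c2nc3c(N4CCN(CC5CC5)CC4)c(Br)cnc3[nH]2)cc1` gives 830 nM and holds the lowest of the two numbers so far, with compound 2 `O=C(CN1CCN(c2c(Br)cnc3[nH]c(-c4ccccc4)nc23)CC1)Nc1nccs1` at 3000 nM as the higher one. Compound 3 `COc1ccc(-c2nc3c(N4CCN(Cc5cncnc5)CC4)c(Br)cnc3[nH]2)cc1` carries pyrimidin-5-yl in place of cyclopropyl on a saturated chain carbon bound to an amine nitrogen in a ring. Going by the values given here, no measured pair shows this change, so only a modest rise in this assay is expected, perhaps none beyond the scatter. The estimated step of a 1.8-fold higher number from compound 1 to compound 3 (0.26 log units; within the scatter) is a tentative expectation. Compound 3 is expected at 1500 nM within an estimated range of 500 nM to 4500 nM in this reading.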

Compound 3, concentration for 50% growth inhibition: 400 nM
Compound 3: the middle estimate sits 3.8-fold (0.57 log units) above what was measured; measured number below the stated range.
By their numbers in this assay, from the lowest: compound 3; then compound 1; then compound 2.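

Pyrimidin-5-yl in place of cyclopropyl on a saturated chain carbon bound to an amine nitrogen in a ring gives a 2.1-fold lower number from compound 1 to compound 3 (0.32 log units; beyond the scatter) in this assay as a modest step. For the compounds shown here, this is the first one-place comparison, and it shows that this position accepts a six-membered aromatic ring with 2 hetero atoms and still gains growth inhibition. Nothing measured here accounts for the step.

The compounds shown leave open whether the ring nitrogens matter, since phenyl at this place would be needed to separate them from the ring itself. They also leave open how pyridin-3-yl or a longer chain ending in the same pyrimidin-5-yl would read.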